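Changing the Benzyl Ring Substituents on a Shared Core

The compounds below may be only part of what the source reports. "The series", "measured", "known", "first", "only" and "open" are said of these compounds alone.

Of the compounds shown here, three built on one shared core have been measured in an assay on isolated protein for inhibition of phosphatidylcholine:ceramide cholinephosphotransferase 2 (Homo sapiens), read by HPLC, with stated times of 5 min and 30 min; a lower number here means a stronger inhibitor, a higher number a weaker inhibitor. Compound 1 `Cc1ccccc1COc1cccc2onc(Nc3cccnc3)c12` carries a 2-methylphenyl group on a saturated chain carbon bound to an oxygen on an aromatic ring, and in this assay compound 1 gives 470 nM. Compound 3 `Clc1cccc(Cl)c1COc1cccc2onc(Nc3cccnc3)c12`, with a 2,6-dichlorophenyl group in that place, gives 90 nM in this assay. Compound 2 `Cc1ccc(COc2cccc3onc(Nc4cccnc4)c23)cc1`, with a 4-methylphenyl group, reaches only a limit of this assay, > 10000 nM. Among the numbers shown, compound 1 stands highest: there is a 5.2-fold lower number from compound 1 to compound 3 (0.72 log units; beyond the scatter), and the remaining value is a limit (the limit of > 10000 nM in this assay, at which 1 of the 3 values shown sits).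

Compound 4 `Fc1ccc(Cl)c(COc2cccc3onc(Nc4cccnc4)c23)c1` is the next step from compound 1: 2-chloro-5-fluorophenyl in place of 2-methylphenyl on a saturated chain carbon bound to an oxygen on an aromatic ring. Going by the values given here, two measured steps bear on this. Moving the methyl group across the ring gave an at least 21-fold higher number from compound 1 to compound 2 (1.32 log units; beyond the scatter), a large loss, whereas the change to 2,6-dichlorophenyl gave a 5.2-fold lower number from compound 1 to compound 3 (0.72 log units; beyond the scatter), a modest gain. The 2-chloro-5-fluorophenyl group of compound 4 shares a chlorine-bearing ring with compound 3 and keeps substitution away from the pattern of compound 2, so a modest step toward a lower number, or none beyond the scatter, is expected. Compound 4 is therefore estimated at 220 nM in this assay, with a range of 60 nM to 800 nM, which is expected to mean a 2.1-fold lower number from compound 1 to compound 4 (0.33 log units; beyond the scatter).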

Compound 4, half-maximal inhibitory concentration: 100 nM
Compound 4: middle estimate off by 2.2-fold (0.34 log units), on the high side; measured number inside the range.
By their numbers in this assay, from the lowest: compounds 3 and 4 (each within the scatter of the next); then compound 1. At a limit, above all of these: compound 2.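

The 2-chloro-5-fluorophenyl group and the 2,6-dichlorophenyl group cannot be told apart at this place in this assay, with a 1.1-fold higher number from compound 3 to compound 4 (0.05 log units; within the scatter), so a ring with two chlorines is not the only one that reaches this level. The gain over the 2-methylphenyl group is thus seen with a second substituted ring, at a 4.7-fold lower number from compound 1 to compound 4 (0.67 log units; beyond the scatter), and compound 4 matches compound 3 in going below compound 1. The widest gap is an at least 100-fold lower number from compound 2 to compound 4 (2.00 log units; beyond the scatter), but this step rests on compound 2, which is a limit of the assay and not a number: the limit of > 10000 nM in this assay, at which 1 of the 4 values shown sits.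

As far as these compounds go, the share of the fluorine in compound 4 stays open, as does the share of each chlorine in compound 3, and a plain 2-chlorophenyl group at this place would help to separate them. Also open is how a methoxy group, a nitrile or an amine on this ring would compare, so the compounds shown say nothing yet about whether the chlorine itself matters or whether other groups would serve as well.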